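Three Near-Zero Readings and a Fourth Variant

The compounds below may be only part of what the source reports. "The series", "measured", "known", "first", "only" and "open" are said of these compounds alone.

Measured in an assay on CHO cells for displacement of a labelled ligand from adenosine receptor A3 (Homo sapiens), read by scintillation counting, with a stated time of 120 min, tested at 10 uM; a higher number here means more inhibition at the concentration tested (going by the name of the read-out), a lower number less inhibition:
compound 1 `Nc1scc(CN2CCN(c3ccc(Cl)c(C(F)(F)F)c3)CC2)c1C(=O)c1ccc(Cl)cc1`: 3%
compound 2 `Nc1scc(CN2CCN(c3ccncc3)CC2)c1C(=O)c1ccc(Cl)cc1`: 2%
compound 3 `Nc1scc(CN2CCN(C3CCCCCC3)CC2)c1C(=O)c1ccc(Cl)cc1`: 0%

All three compounds share one core and differ only in the group attached to the amine nitrogen in the ring. Compound 3 has the lowest of the three numbers, but its nearest neighbour compound 2 and its furthest neighbour compound 1 both sit within the usual scatter of it, so nothing separates the three in this assay.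

Compound 4 `Nc1scc(CN2CCN(c3ccc(F)cc3F)CC2)c1C(=O)c1ccc(Cl)cc1` is the next variant. Its change from compound 3 is 2,4-difluorophenyl in place of cycloheptyl on an amine nitrogen in a ring.

Going by the values given here, two measured steps bear on this change, each replacing a ring on that nitrogen with cycloheptyl: a number 3 percentage points lower from compound 1 to compound 3 (within the scatter) and a number 2 percentage points lower from compound 2 to compound 3 (within the scatter). The reverse direction, cycloheptyl giving way to an aromatic ring, is now taken, and with every step among compounds 1, 2 and 3 within the scatter, no step beyond the scatter is expected for compound 4 either, in either direction; the expected step is a number 2 percentage points higher from compound 3 to compound 4 (within the scatter).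

Compound 4 is therefore estimated at 2% in this assay, with a range from -6% to 10%.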

Compound 4, a percentage reported as inhibition, at one concentration (the size of the read-out at that concentration, not a potency): 0%
The estimate for compound 4 lay 2 percentage points above the measured number; the range from low to high includes it.
By their numbers in this assay, from the lowest: compounds 3, 4, 2 and 1 (each within the scatter of the next).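

In this assay, the change from a saturated carbon ring to a fluorinated aromatic ring on the ring nitrogen gives no change at the digits printed from compound 3 to compound 4 (within the scatter), so this direct swap of cycloheptyl for 2,4-difluorophenyl does not lift the reading out of the scatter. Set against the two other aromatic groups at this position, 2,4-difluorophenyl gives a number 2 percentage points lower from compound 2 to compound 4 (within the scatter) and a number 3 percentage points lower from compound 1 to compound 4 (within the scatter), which means that a fluorine-bearing phenyl ring now joins a chlorinated and trifluoromethylated phenyl ring, a pyridine ring and a cycloheptyl ring, with no step among the four compounds lying beyond the scatter. Nothing available explains why these readings stay together.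

From the compounds shown here alone, all four compounds keep the shared core and vary only this one substituent, so it remains open whether a group of another kind on that nitrogen, such as a longer chain ending in a carboxylic acid or an amine, would move the reading beyond the scatter. Going by these compounds, it also remains open whether a change elsewhere on the core, such as replacing the chlorine on the benzoyl ring with a methoxy group, would do so.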